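A few compounds are considered here, and "the series" means these few. Any claim that something is new, unique, unknown or untested is made for them only; others in the source may bear on it.

In a functional assay on Bel-7402 cells (Homo sapiens) for cytotoxicity, read by MTT assay, with a stated time of 72 h (on this read-out lower numbers stand for stronger inhibition and higher numbers for weaker inhibition), compound 1 `O=C1C=CCC/C1=C\C=C\c1ccc(Cl)cc1` gives 3200 nM and compound 2 `O=C1C=CCC/C1=C\C=C\c1ccc(Br)cc1` gives 3600 nM. With only these two numbers measured, compound 2 stands level with compound 1 within the usual scatter. Compound 3 `O=C1C=CCC/C1=C\C=C\c1ccc([N+](=O)[O-])cc1` keeps the shared core but carries nitro in place of bromo on an aromatic carbon, para to a large group: nitro in place of bromo on an aromatic carbon. Among the compounds with values here, the only measured step that bears on this change is a 1.1-fold higher number from compound 1 to compound 2 (0.05 log units; within the scatter), which came from putting bromo in place of chloro at that same spot. Within the data shown here, no measured compound carries nitro, so that step offers only a loose guide. No step beyond the scatter is therefore expected in this assay, although the margin must stay wide. The expected step is a 1.2-fold lower number from compound 2 to compound 3 (0.08 log units; within the scatter). For compound 3 the estimated value is 3000 nM, with an expected range from 1100 nM to 8000 nM.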

Compound 3, half-maximal inhibitory concentration: 4200 nM
Compound 3: middle estimate off by 1.4-fold (0.15 log units), on the low side; the measured number falls inside the stated range.
By their numbers in this assay, from the lowest: compounds 1, 2 and 3 (each within the scatter of the next).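

In this assay, nitro in place of bromo gives a 1.2-fold higher number from compound 2 to compound 3 (0.07 log units; within the scatter) and nitro in place of chloro gives a 1.3-fold higher number from compound 1 to compound 3 (0.12 log units; within the scatter) on the same aromatic carbon, para to a large group. This position has now carried a group of 3 heavy atoms and 2 hydrogen-bond acceptors as well as single-atom halogens, and all three compounds remain level within the scatter. No measurement here offers an explanation for this closeness.

What an amine, a carboxylic acid or a longer alkyl chain would do at this spot remains open, since the groups shown are only chloro, bromo and nitro. Also open, from the compounds shown here alone, is whether these groups would stay as closely matched on a different carbon of the ring.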